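Replacing Piperidine with an Anilino Group on a Quinazoline Core

A few compounds are considered here, and "the series" means these few. Any claim that something is new, unique, unknown or untested is made for them only; others in the source may bear on it.

The measured compounds so far:
compound 1, `CCCCCCNc1nc(SCc2ccc(C(F)(F)F)cc2)nc2ccccc12`, 19000 nM
compound 2, `FC(F)(F)c1ccc(CSc2nc(N3CCCCC3)c3ccccc3n2)cc1`, 25500 nM

Both were tested in a functional assay on PC-3 cells (Homo sapiens) for cytotoxicity, read by MTT assay, with a stated time of 72 h; a lower number here means a stronger inhibitor, a higher number a weaker inhibitor. Compound 2, with 25500 nM, stands within the usual scatter of compound 1, as the step of a 1.3-fold higher number from compound 1 to compound 2 (0.13 log units; within the scatter) shows; neither compound is a strong inhibitor on this scale.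

Compound 3, `FC(F)(F)c1ccc(CSc2nc(Nc3ccccc3C(F)(F)F)c3ccccc3n2)cc1`, is not yet measured. It differs from compound 2 by (2-(trifluoromethyl)phenyl)amino in place of piperidin-1-yl on an aromatic carbon. Among the compounds with values here, the only measured step, a 1.3-fold higher number from compound 1 to compound 2 (0.13 log units; within the scatter), swapped one saturated nitrogen substituent for another and changed little; no measured step introduces an aromatic amine at this position, so the data give no direct guide. The expectation for compound 3 in this assay is therefore a number in the same weak range, with a wide margin: the estimated step is a 1.7-fold lower number from compound 2 to compound 3 (0.23 log units; within the scatter). Compound 3 is estimated at 15000 nM, with a range from 4000 nM to 60000 nM.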

Compound 3, half-maximal inhibitory concentration: 34800 nM
Estimate against measurement, compound 3: 2.3-fold (0.37 log units) below; measured number inside the range.
By their numbers in this assay, from the lowest: compounds 1, 2 and 3 (each within the scatter of the next).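

In this assay the swap of piperidin-1-yl for (2-(trifluoromethyl)phenyl)amino gives a 1.4-fold higher number from compound 2 to compound 3 (0.14 log units; within the scatter) and the swap of hexyl for 2-(trifluoromethyl)phenyl on the nitrogen gives a 1.8-fold higher number from compound 1 to compound 3 (0.26 log units; within the scatter) for the two pairs that include the new compound. Within the data shown here, this position had so far been seen only with a chain and a non-aromatic ring, and it now also carries an aromatic ring, yet these three groups cannot be told apart in this cell assay. Nothing measured here bears on why the three numbers lie so close together.

Open, from the compounds shown here alone, is whether any group at this position can move the number beyond the usual scatter. A plain phenylamino group without the trifluoromethyl, or a morpholin-4-yl ring in place of piperidin-1-yl, would test this on the same shared core.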